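The compounds below may be only part of what the source reports. "The series", "measured", "known", "first", "only" and "open" are said of these compounds alone.

Compound 1 (`COc1cc(/C=C/C(=O)c2cccc(NC(=O)c3cc(Cl)cc(Cl)c3)c2)ccc1O`) gives (> 50 ug/mL), a limit
Compound 2 (`COc1cc(/C=C/C(=O)c2cccc(NC(=O)C(C)C)c2)ccc1O`) gives (3.47 ug/mL)

For the measured compounds named here, in a functional assay on Vero cells (Chlorocebus sabaeus) for inhibition (on this read-out lower numbers stand for stronger inhibition and higher numbers for weaker inhibition), compound 2 gives 3.47 ug/mL and is the only compound with an actual number so far. Compound 3 (`CCCC(=O)Nc1cccc(C(=O)/C=C/c2ccc(O)c(OC)c2)c1`) carries propyl in place of isopropyl on a carbonyl carbon. Going by the values given here, the one measured step (an at least 14-fold lower number from compound 1 to compound 2 (1.15 log units; beyond the scatter)) is large, but it exchanged 3,5-dichlorophenyl for isopropyl, a far bigger change, so it offers little guidance here. Only a small move within the scatter is therefore expected in this assay, with no clear direction (a 1.2-fold higher number from compound 2 to compound 3 (0.06 log units; within the scatter)). For compound 3 the estimated value is 4 ug/mL (expected range 1.5 ug/mL to 12 ug/mL).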

Compound 3, half-maximal inhibitory concentration: 2.04 ug/mL
Compound 3: the middle estimate sits 2.0-fold (0.29 log units) above what was measured, within the range that was stated.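

In this assay, isopropyl and propyl on this carbonyl carbon cannot be told apart, with a 1.7-fold lower number from compound 2 to compound 3 (0.23 log units; within the scatter), so the exact arrangement of these two chains makes no clear difference here. Propyl also gives a large separation from 3,5-dichlorophenyl at the same place, with an at least 24-fold lower number from compound 1 to compound 3 (1.38 log units; beyond the scatter). That separation rests on a limit for compound 1, not on a number: the limit of > 50 ug/mL in this assay, at which 1 of the 3 values shown sits.

The compounds shown leave open whether a longer chain such as hexyl, or a chain ending in an amine, would hold this level. They also leave open whether an unsubstituted phenyl would behave like propyl or like 3,5-dichlorophenyl.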